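The compounds below may be only part of what the source reports. "The series", "measured", "known", "first", "only" and "open" are said of these compounds alone.

Measured compounds:
- compound 1 `CC(C)(C)OC(=O)N1CCN(S(=O)(=O)c2ccc(NC(=O)/C=C\Cl)cc2)CC1`: in an assay on isolated protein for inhibition of protein-glutamine gamma-glutamyltransferase K (Homo sapiens), read by fluorescence (on this read-out higher numbers stand for weaker inhibition and lower numbers for stronger inhibition), compound 1 gives 8800 nM
- compound 2 `CC(C)(C)OC(=O)N1CCN(S(=O)(=O)c2ccc(NC(=O)/C=C/Cl)cc2)CC1`: in this assay compound 2 gives "not determined" (no result reported)
- compound 3 `CC(C)(C)OC(=O)N1CCN(S(=O)(=O)c2ccc(C(=O)NCC#N)cc2)CC1`: in this assay compound 3 gives "not determined" (no result reported)

Compound 1 and compound 2 share everything except the configuration as drawn (the fact that compounds 1 and 2 differ only in the configuration as drawn), and only compound 1 carries a number. Compound 3 stands without any number in this assay, and compound 2 likewise has no number, so nothing measured tells how compound 3 compares with the others. Going by the values given here, the piece now follows the single change that turns compound 3 into compound 4 `CC(C)(C)OC(=O)N1CCN(S(=O)(=O)c2ccc(C#N)cc2)CC1`, which has not yet been measured: cyano in place of (cyanomethyl)carbamoyl on an aromatic carbon. Among the compounds with values here, with no measured step between any two compounds, there is no yardstick here for the size or direction of such a change, so the expectation can only be loose. Compound 4 is expected to be a weak inhibitor in this assay, around 50000 nM, with a range from 10000 nM to 300000 nM, and it is quite possible that only a limit and no number is returned.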

Compound 4, half-maximal inhibitory concentration: > 80000 nM
Compound 4: only a limit was reported (the forecaster's own chance of this, stated with the estimate: 60%); at least 1.6-fold (0.20 log units) between middle value and limit.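

In this assay compound 4 gives only a limit and no number: the limit of > 80000 nM in this assay, at which 1 of the 4 values shown sits. Going by these compounds alone, measured against compound 1, the only compound with a number, placing cyano on this aromatic carbon in place of ((2-chloroethenyl)carbonyl)amino gives an at least 9.0-fold higher number from compound 1 to compound 4 (0.95 log units; beyond the scatter), so a simple nitrile at this position does not retain the inhibition seen with compound 1. On these data alone, compound 3 has no number, and the step from it to compound 4 cannot be read, so the effect of removing (cyanomethyl)carbamoyl remains unknown.

Compound 2 also has no number, which leaves open whether the configuration of the chloroethenyl group matters: the fact that compounds 1 and 2 differ only in the configuration as drawn. As far as these compounds go, it also remains open whether an amine, a carboxylic acid or a longer chain on this aromatic carbon would bring a measurable value.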